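The compounds below may be only part of what the source reports. "The series", "measured", "known", "first", "only" and "open" are said of these compounds alone.

For the measured compounds named here, in an ADME assay on MT4 cells (Homo sapiens) for cytotoxicity, read by MTT assay, with a stated time of 5 days (a lower number here means that less compound is tolerated, a higher number that more compound is tolerated), compound 2 (`COc1cc2nc([S+]([O-])CC(=O)Nc3cccc(C(F)(F)F)c3)nc(Nc3c(Cl)cc(/C=C/C#N)cc3Cl)c2cc1OC`) gives 21800 nM as the only exact number so far. Compound 1 (`COc1cc2nc([S+]([O-])CC(=O)Nc3ccccc3C(F)(F)F)nc(Nc3c(Cl)cc(/C=C/C#N)cc3Cl)c2cc1OC`) stands at > 192000 nM as a limit of the assay and not a number. Going by the values given here, the one measured step is an at least 8.8-fold lower number from compound 1 to compound 2 (0.94 log units; beyond the scatter) when 3-(trifluoromethyl)phenyl replaces 2-(trifluoromethyl)phenyl on an amide-type nitrogen, and it rests on the limit of > 192000 nM in this assay, at which 1 of the 2 values shown sits, at its upper end. Compound 3 (`COc1cc2nc([S+]([O-])CC(=O)Nc3cc([N+](=O)[O-])ccc3F)nc(Nc3c(Cl)cc(/C=C/C#N)cc3Cl)c2cc1OC`) changes that same place, with 2-fluoro-5-nitrophenyl in place of 3-(trifluoromethyl)phenyl on an amide-type nitrogen is the whole difference. The earlier step shows that a change here can move the number, but it sets no direction for this new group. The expected outcome is a 1.1-fold higher number from compound 2 to compound 3 (0.06 log units; within the scatter) in this assay with no firm direction and probably nothing clearly beyond the scatter. For compound 3 the estimate is 25000 nM within an expected range from 7000 nM to 100000 nM in this assay.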

Compound 3, half-maximal cytotoxic concentration: > 194000 nM
Compound 3 gave a limit, no number; the forecaster's own chance of this, stated with the estimate: 20%; middle value at least 7.7-fold (0.88 log units) away from the limit.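

In this assay, the place on the amide-type nitrogen can now move the number in either direction: the earlier step lowered it, while 2-fluoro-5-nitrophenyl in place of 3-(trifluoromethyl)phenyl gives an at least 8.8-fold higher number from compound 2 to compound 3 (0.94 log units; beyond the scatter). Compound 3 stands at a limit of the assay and not at a number: the limit of > 194000 nM in this assay, at which 1 of the 3 values shown sits. The step joining compound 1 and compound 3 cannot be read, and of the three aryl groups shown, only the 3-(trifluoromethyl)phenyl of compound 2 gives an exact number.

From the compounds shown here alone, it remains open whether the fluoro or the nitro group of 2-fluoro-5-nitrophenyl would carry this step alone, and what an amine or a carboxylic acid on the same ring would do. Going by these compounds, how far the true values of compound 1 and compound 3 lie beyond their limits also remains unknown.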